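Morpholin-2-yl ether variation on the core of compound 3

This account rests on a few compounds, and the source may have more. Where it says the series, first, only, none or still open, it means among the compounds named here.

Working notes on the series. Compound 1 `O=C(NC1CCN(CC2CC2)C1)c1cc(-c2ccc(NS(=O)(=O)c3cccc(Cl)c3Cl)cc2)nc2[nH]ncc12` gives 35 nM in an assay for inhibition of serine/threonine-protein kinase Sgk1 (Homo sapiens), with stated times of 30 min and 60 min, in the presence of a further agent that is not named here; on this read-out higher numbers stand for weaker inhibition and lower numbers for stronger inhibition. Compound 2 `CN1CC(NC(=O)c2cc(-c3ccc(NS(=O)(=O)c4cccc(Cl)c4Cl)cc3)nc3[nH]ncc23)C1` sits at the assay limit, < 1 nM, a limit and not a number (the limit of < 1 nM in this assay, at which 1 of the 3 values shown sits). Compound 3 `CCOc1nc(-c2ccc(NS(=O)(=O)c3cc(Cl)ccc3F)cc2)nc2[nH]nc(C)c12` gives 183 nM in this assay, the highest of the two numbers shown; its nearest neighbour is compound 1, an at least 35-fold lower number from compound 1 to compound 2 (1.54 log units; beyond the scatter) being the only measured step, and that step concerns the amide-type nitrogen of a different core.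

Compound 4 `Cc1n[nH]c2nc(-c3ccc(NS(=O)(=O)c4cc(Cl)ccc4F)cc3)nc(OCC3CNCCO3)c12` carries morpholin-2-yl in place of methyl on a saturated chain carbon bound to an oxygen on an aromatic ring. Within the data shown here, no measured step touches this position, so the only comparison is indirect: the change from compound 1 to compound 2, on another part of the molecule, replaced one saturated nitrogen ring with another and gave a large lower number. For compound 4 an expected step of a 3.1-fold lower number from compound 3 to compound 4 (0.48 log units; beyond the scatter) toward a lower number is taken, with wide uncertainty. Compound 4 is estimated at 60 nM in this assay, within 15 nM to 250 nM.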

Compound 4, half-maximal inhibitory concentration: 2 nM
The estimate for compound 4 lay 30-fold (1.48 log units) above the measured number, outside the stated range (below it).
By their numbers in this assay, from the lowest: compound 4; then compound 1; then compound 3. At a limit, below all of these: compound 2.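

Among these compounds, the ether on the shared core now has a measured step, where the earlier compounds gave none: in this assay, (morpholin-2-yl)methoxy in place of ethoxy gives a 92-fold lower number from compound 3 to compound 4 (1.96 log units; beyond the scatter). The number therefore responds strongly to what is carried on this saturated chain carbon, and a six-membered ring with two hetero atoms is accepted there, in the same direction as the large step on the amide-type nitrogen of the other core, an at least 35-fold lower number from compound 1 to compound 2 (1.54 log units; beyond the scatter). Nothing measured here accounts for the size of this step.

The change brought in the ring, its amine and its ring oxygen together, so the compounds shown leave open which of these carries the step. An open-chain 2-aminoethoxy group or an all-carbon cyclohexylmethoxy group in this place would begin to separate them.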